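Replacing a 3-methoxycyclobutyl amide with a 3-chlorophenyl amide

The source may report more compounds than this note shows. Statements on the series, on what has been measured and on what is new or still open speak of the compounds shown alone.

Compound 1 `CN1CCc2nc(C#Cc3ccccc3)sc2C1` gives > 10000 nM in an assay on HEK293 cells for negative allosteric modulation of metabotropic glutamate receptor 5 (Homo sapiens), read by FLIPR, with a stated time of 1 h (a higher number here means a weaker inhibitor, a lower number a stronger inhibitor), which is a limit of the assay.
Compound 2 `COC1CC(C(=O)N2CCc3nc(C#Cc4ccccc4)sc3C2)C1` gives > 10000 nM, again a limit of the assay.

Both values shown are limits, as the limit of > 10000 nM in this assay, at which 2 of the 2 values shown sit, records, so the step that the two limits leave unreadable from compound 1 to compound 2 remains unreadable. Compound 2 therefore stands only at the limit, with no number of its own. Compound 3 `O=C(c1cccc(Cl)c1)N1CCc2nc(C#Cc3ccccc3)sc2C1` differs from compound 2 by 3-chlorophenyl in place of 3-methoxycyclobutyl on a carbonyl carbon. For the measured compounds named here, no measured step touches the group on the carbonyl carbon, so no size can be carried over to this change. The step is estimated as an at least 1.2-fold lower number from compound 2 to compound 3 (0.09 log units; that floor lies within the scatter). Compound 3 is expected to give 8000 nM, in a range from 1500 nM to 30000 nM.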

Compound 3, half-maximal inhibitory concentration: > 10000 nM
Compound 3 gave a limit, no number; the forecaster's own chance of this, stated with the estimate: 55%; at least 1.2-fold (0.09 log units) between middle value and limit.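

Compound 3 gives > 10000 nM in this assay and that value is a limit of the assay, so no step can be read between compound 2 and compound 3. The compounds shown leave open what number any of them would have and which group on the carbonyl carbon would give a measurable value.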